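The source may hold more compounds than are shown below. What is called first, only, known or untested is meant among the compounds shown, and "the series" means these compounds.

Measured in a functional assay on the whole organism (strain albino) with Rattus norvegicus as the target, in the maximal electroshock model, with a stated time of 1 h, at a dose of 30 mg/kg by the intraperitoneal route; a higher number here means more inhibition at the dose given (going by the name of the read-out), a lower number less inhibition:

- compound 1 `CCOC(=O)CNn1c(C)nc2ccc(Br)cc2c1=O` gives 20%
- compound 2 `CCOC(=O)CNn1c(C)nc2ccccc2c1=O` gives 20%

Within the data shown here, only one step is available between the two, no change at the digits printed from compound 1 to compound 2 (within the scatter). Compound 2 therefore stands level with compound 1 at the digits shown, within the scatter; neither number can be called the higher.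

Compound 3 `Cc1nc2ccccc2c(=O)n1NCC(=O)NNC(N)=S` differs from compound 2 by a group of 5 heavy atoms (1 carbon, 3 nitrogen, 1 sulfur; no ring) in place of a group of 3 heavy atoms (2 carbon, 1 oxygen; no ring), on a carbonyl carbon. Among the measured compounds shown here, the single measured step concerns a bromo on an aromatic carbon and says nothing about the ethoxy on the carbonyl carbon, so no measured step bears on this change and no direction can be drawn from the series. The expectation for compound 3 accordingly rests on compound 2 and its value of 20%, with a wide range to allow for an unexplored change. Compound 3 is estimated at 25%, between 0% and 65%. The step this estimate implies, a number 5 percentage points higher from compound 2 to compound 3 (within the scatter), is expected to stay within the scatter.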

Compound 3, a percentage reported as inhibition, in the whole organism at one dose (the size of the read-out at that dose, not a potency): 30%
Beside the measured number, compound 3's estimate is 5 percentage points below it, within the range that was stated.
By their numbers in this assay, from the lowest: compounds 1, 2 and 3 (each within the scatter of the next).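

Replacing the ethoxy on the carbonyl carbon in this assay gives a number 10 percentage points higher from compound 2 to compound 3 (within the scatter) with the core unchanged. Among these compounds, this is the first reading at this carbonyl carbon, as the earlier step concerned only the bromo on an aromatic carbon. Even an exchange of this size, to a group of 5 heavy atoms (1 carbon, 3 nitrogen, 1 sulfur; no ring), therefore does not separate the two compounds in this assay. No available evidence bears on this result.

On these data alone, whether a carboxylic acid or an amine on the same carbonyl carbon would move the number beyond the scatter remains open. So does whether the bromo of compound 1, combined with the group in compound 3, would leave the reading unchanged.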